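The source may hold more compounds than are shown below. What is called first, only, known or untested is meant among the compounds shown, and "the series" means these compounds.

Compound 1 `COc1cc(-c2ccnc3cc(-c4ccc(Cl)cc4)nn23)cc(OC)c1OC` gives 3340 nM in a functional assay on HCT-116 cells (Homo sapiens) for inhibition, read by CCK-8 assay, with a stated time of 48 h (a higher number here means a weaker inhibitor, a lower number a stronger inhibitor), the highest of the two numbers in the series. Compound 3 `COc1ccc(-c2cc3nccc(-c4cc(OC)c(OC)c(OC)c4)n3n2)cc1`, which differs from it only by methoxy in place of chloro on an aromatic carbon, gives 404 nM, a step of an 8.3-fold lower number from compound 1 to compound 3 (0.92 log units; beyond the scatter). Compound 2 `COc1cc(-c2cc3nccc(-c4c[nH]c5ccccc45)n3n2)cc(OC)c1OC` reaches only a limit, > 10000 nM, of the kind (the limit of > 10000 nM in this assay, at which 1 of the 3 values shown sits). Compound 4 `COc1cc(-c2ccnc3cc(-c4ccc5c(ccn5C)c4)nn23)cc(OC)c1OC` carries 1-methyl-1H-indol-5-yl in place of 4-chlorophenyl on an aromatic carbon. Among the compounds with values here, no measured step matches this exchange; the one step that touches the same carbon, an 8.3-fold lower number from compound 1 to compound 3 (0.92 log units; beyond the scatter), shows that the position admits a change of substituent with a modest gain. Within the data shown here, with no closer precedent, the expectation for compound 4 is a step of a 1.7-fold lower number from compound 1 to compound 4 (0.22 log units; within the scatter), hardly beyond the scatter, to about 2000 nM (range 500 nM to 8000 nM).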

Compound 4, half-maximal inhibitory concentration: 39 nM
Compound 4: the middle estimate sits 51-fold (1.71 log units) above what was measured; the whole stated range lies above it.
By their numbers in this assay, from the lowest: compound 4; then compound 3; then compound 1. At a limit, above all of these: compound 2.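

In this assay, the two-ring 1-methyl-1H-indol-5-yl on this aromatic carbon gives an 86-fold lower number from compound 1 to compound 4 (1.93 log units; beyond the scatter) and a 10-fold lower number from compound 3 to compound 4 (1.02 log units; beyond the scatter). The position therefore accepts more than a substituted phenyl, and the exchange of the whole group goes further than the methoxy exchange alone, an 8.3-fold lower number from compound 1 to compound 3 (0.92 log units; beyond the scatter). Nothing shown accounts for this gain.

Still open, from the compounds shown here alone, is whether the 1-methyl group is needed, or whether a longer chain such as propyl, or a chain ending in an amine, holds this level. A carboxylic acid on the indole is equally untested here.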